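Trimming the methyl from the sulfonyl aryl ring of compound 2

The compounds below may be only part of what the source reports. "The series", "measured", "known", "first", "only" and "open" are said of these compounds alone.

Compound 1 `CCOC(=O)c1oc2ccc(NS(=O)(=O)c3ccc(F)cc3)cc2c1C` gives, in a functional assay on HCT-116 cells (Homo sapiens) for inhibition, read by MTT assay, with a stated time of 72 h (a lower number here means a stronger inhibitor, a higher number a weaker inhibitor), a limit of > 40000 nM.
Compound 2 `CCOC(=O)c1oc2ccc(N(Cc3ccccc3)S(=O)(=O)c3ccc(C)cc3)cc2c1C` gives a limit of > 40000 nM in this assay.
Compound 3 `CCOC(=O)c1oc2ccc(N(Cc3ccccc3)S(=O)(=O)c3ccc(Cl)cc3)cc2c1C` gives 23200 nM in this assay.

Compound 2 sits at the ceiling of this assay: the limit of > 40000 nM in this assay, at which 2 of the 3 values shown sit, so only a limit and no number is known for it. Compound 4 `CCOC(=O)c1oc2ccc(N(Cc3ccccc3)S(=O)(=O)c3ccccc3)cc2c1C` differs from compound 2 by hydrogen in place of methyl on an aromatic carbon. Going by the values given here, the only measured step that alters the same group, an at least 1.7-fold lower number from compound 2 to compound 3 (0.23 log units; that floor lies within the scatter), stays within the scatter, and compound 1 also sits at the limit. Replacing methyl by hydrogen is therefore expected to move the number little if at all, a number no higher from compound 2 to compound 4 (the limit leaves the size open). Compound 4 is thus estimated at 40000 nM, within 15000 nM to 100000 nM, and will most likely again be reported only as a limit.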

Compound 4, half-maximal inhibitory concentration: > 40000 nM
Compound 4: no number, only a limit; the forecaster's own chance of this, stated with the estimate: 65%; the middle value lies on the limit itself.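

With hydrogen on this aromatic carbon, compound 4 stays at the limit of this assay, so among the compounds carrying the benzyl group on the sulfonamide nitrogen, only the chloro compound gives a number. Hydrogen in place of chloro gives an at least 1.7-fold higher number from compound 3 to compound 4 (0.23 log units; that floor lies within the scatter), so even this step cannot be told from the scatter. The step between the two limits, compound 2 and compound 4, cannot be read, and the ceiling now holds most of the series: the limit of > 40000 nM in this assay, at which 3 of the 4 values shown sit.

On these data alone, how far compound 2 and compound 4 lie beyond the limit stays open. So does whether bromo or methoxy on this carbon would give a clearer number.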